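Methyl on the hydroxymethyl carbon of compound 3

The source may hold more compounds than are shown below. What is called first, only, known or untested is meant among the compounds shown, and "the series" means these compounds.

Of the compounds shown here, three sharing one core have been measured in an ADME assay on the whole organism (Mus musculus, strain C57BL/6J) for pharmacokinetics, with a stated time of 24 h, at a dose of 2 mg/kg by the intravenous route; on this read-out higher numbers stand for fast clearance and lower numbers for slow clearance. Compound 1 `CCc1cnc(OCC(C)(C)O)c(-c2ccc(S(C)(=O)=O)cc2)c1` gives 65.6 mL/min/kg, compound 2 `CCCOc1nc(OCC(C)(C)O)c(-c2ccc(S(C)(=O)=O)cc2)cc1CO` gives 92.7 mL/min/kg and compound 3 `CCCCOc1nc(OCC(C)(C)O)c(-c2ccc(S(C)(=O)=O)cc2)cc1CO` gives 101 mL/min/kg. Compound 3 therefore stands within the scatter of both of the others, and the three numbers cannot be ranked.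

The next structure is compound 4 `CCCCOc1nc(OCC(C)(C)O)c(-c2ccc(S(C)(=O)=O)cc2)cc1C(C)O`. The difference from compound 3 is methyl in place of hydrogen on a saturated chain carbon bound to an aromatic carbon and an oxygen on a saturated carbon. Cut one bond further out, it reads hydroxymethyl to 1-hydroxyethyl.

Among the compounds with values here, only one measured step bears on this change. That step, a 1.1-fold higher number from compound 2 to compound 3 (0.04 log units; within the scatter), also puts methyl in place of hydrogen on a saturated chain carbon, but three bonds along the chain from an oxygen on an aromatic ring. It lies elsewhere in the molecule, so it is only a loose guide. Within the data shown here, no measured pair tests the hydroxymethyl carbon itself.

On this evidence, no change beyond the scatter is expected in this assay, and neither direction is clearly favoured. The estimated step is a 1.1-fold lower number from compound 3 to compound 4 (0.03 log units; within the scatter). Compound 4 is expected at 95 mL/min/kg, with an estimated range from 55 mL/min/kg to 150 mL/min/kg.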

Compound 4, clearance: 48.2 mL/min/kg
Estimate against measurement, compound 4: 2.0-fold (0.29 log units) above; measured number below the stated range.
By their numbers in this assay, from the lowest: compounds 4, 1, 2 and 3 (each within the scatter of the next, the first and the last beyond it).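

In this assay, within the data shown here, the change from hydroxymethyl to 1-hydroxyethyl gives a 2.1-fold lower number from compound 3 to compound 4 (0.32 log units; beyond the scatter), which makes it the first change at a single place in these compounds to go beyond the scatter. Among these compounds, the only earlier such step, a 1.1-fold higher number from compound 2 to compound 3 (0.04 log units; within the scatter), also put methyl in place of hydrogen, but on a saturated chain carbon three bonds along the chain from an oxygen on an aromatic ring. Within this small set, the same replacement therefore cannot be read as interchangeable between the two places, and the carbon bound to an aromatic carbon and an oxygen is the one where it shifts the clearance number beyond the scatter. Nothing measured in these compounds accounts for the size of this step or says what lies behind it.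

On these data alone, it remains open whether a second methyl on the same carbon, an ethyl in place of the new methyl, or a methoxy in place of the hydroxyl would lower the number further, hold it or reverse the step. As far as these compounds go, it is also open whether 1-hydroxyethyl would give a comparable step on the shorter chain of compound 2, since one pair at one place cannot show how general the change is.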